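A few compounds are considered here, and "the series" means these few. Any claim that something is new, unique, unknown or untested is made for them only; others in the source may bear on it.

Working notes on the series. Within the data shown here, compound 1 `COc1cc2c(Oc3ccc(NC(=O)c4nccc(-c5ccc(C)cc5)n4)cc3F)ccnc2cc1OCCCN1CCCCC1` is the only member with a number so far: in a functional assay on U-87MG ATCC cells (Homo sapiens) for cytotoxicity, read by MTT assay, with a stated time of 72 h (on this read-out lower numbers stand for stronger inhibition and higher numbers for weaker inhibition), compound 1 gives 1140 nM. Compound 2 `COc1cc2c(Oc3ccc(NC(=O)c4nccc(-c5ccc(F)cc5)n4)cc3F)ccnc2cc1OCCCN1CCCCC1` carries "not determined" (no result reported) in this assay, so no result is available for it. Compound 3 `COc1cc2c(Oc3ccc(NC(=O)c4nccc(-c5ccc(C)cc5)n4)cc3F)ccnc2cc1OCCCN1CCN(C)CC1` likewise carries "not determined" (no result reported) in this assay, so compound 3 stands without a number of its own, and compound 2 shares this gap; the one reference point available is compound 1. Compound 4 `COc1cc2c(Oc3ccc(NC(=O)c4nccc(-c5ccc(F)cc5)n4)cc3F)ccnc2cc1OCCCN1CCN(C)CC1` is the member still to be measured in this assay. The change from compound 3 to compound 4 is fluoro in place of methyl on an aromatic carbon. No pair of measured compounds that differ in one place exists in this set, so nothing here shows how this exchange moves the read-out; a step of this kind in this assay is expected to stay within the usual scatter, with no clear direction. Compound 4 departs from compound 1 in two places, and because compound 1 gives 1140 nM the estimate for compound 4 is anchored there with a wide band. Compound 4 is expected to give 1200 nM in this assay, with a range from 300 nM to 5000 nM.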

Compound 4, half-maximal inhibitory concentration: 910 nM
Compound 4: the middle estimate sits 1.3-fold (0.12 log units) above what was measured, within the range that was stated.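

No new step can be read from compound 4: compound 3, its one-place neighbour, stands without a single number. The compounds shown leave open how going from 4-methylphenyl to 4-fluorophenyl moves the read-out. Nothing shown offers an explanation for the result of compound 4.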